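Sulfonylurea amide series: compound 4 from compound 3

The compounds below may be only part of what the source reports. "The series", "measured", "known", "first", "only" and "open" are said of these compounds alone.

Compound 3 `COc1ccc(Cl)cc1C(=O)NCCC1CCN(S(=O)(=O)NC(=O)NC[C@@H]2C[C@@H]3C=C[C@@H]2C3)CC1` is the highest of the three numbers measured in a functional assay on the whole organism (blood) with Rattus norvegicus as the target, with stated times of 24 h and 1 h, at a dose of 5 mg/kg by the intraperitoneal route; a higher number here means a stronger effect of the compound at the dose given, a lower number a weaker effect: compound 3 gives 37%. Compound 1 `COc1ccc(Cl)cc1C(=O)NCC1CCN(S(=O)(=O)NC(=O)NC2CCCCC2)CC1` gives 20%, a lower number and beyond the scatter, and compound 2 `COc1ccc(Cl)cc1C(=O)NCC1CCN(S(=O)(=O)NC(=O)NC[C@@H]2C[C@@H]3C=C[C@@H]2C3)CC1` gives 15%, also a lower number and beyond the scatter.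

Compound 4 `COc1ccc(Cl)cc1C(=O)NCCC1CCN(S(=O)(=O)NC(=O)NC[C@@H]2C[C@@H]3CC[C@@H]2O3)CC1` differs from compound 3 in one place: a group of 7 heavy atoms (6 carbon, 1 oxygen; 2 five-membered non-aromatic rings with 1 hetero atom each) in place of a group of 7 heavy atoms (7 carbon; 2 five-membered non-aromatic rings of carbon only), on a saturated chain carbon bound to an amide-type nitrogen.

Among the measured compounds shown here, one measured step bears on this kind of change. It is the exchange of ring groups on the amide-type nitrogen, a number 5 percentage points lower from compound 1 to compound 2 (within the scatter), which left the read-out unchanged within the scatter. The present change also exchanges one bicyclic group for another on the same side of the molecule, now with one hetero atom in each five-membered ring. For the measured compounds named here, nothing in the measured compounds shows what an oxygen in that group does, so the expectation rests on the one step that exists.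

Compound 4 is therefore expected to stay close to compound 3, with an estimated step of a number 3 percentage points lower from compound 3 to compound 4 (within the scatter), not beyond the scatter. The estimate for compound 4 in this assay is 34%, with a range from 18% to 50%.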

Compound 4, a percentage reported as activity, at one dose (the size of the read-out at that dose, not a potency): 30%
Compound 4: middle estimate off by 4 percentage points, on the high side; low and high end bracket the measured number.
By their numbers in this assay, from the lowest: compounds 2, 1, 4 and 3 (each within the scatter of the next, the first and the last beyond it).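

In this assay, among the compounds shown here, the first exchange at this position, on a saturated chain carbon bound to an amide-type nitrogen, gives a number 7 percentage points lower from compound 3 to compound 4 (within the scatter) and so shows that the read-out at this dose survives replacing the all-carbon bicyclic group with one carrying a hetero atom in each five-membered ring. The same step also removes the double bond outside aromatic rings, so the contributions of the oxygen and of the lost double bond cannot be separated. No measurement of any property of these two groups accompanies the result, and it offers no explanation for it.

Still open, going by these compounds, is whether the saturated all-carbon bicyclic group would match compound 3 or compound 4. Also open, on these data alone, is whether an amine or a carboxylic acid on this bicyclic group would keep the read-out within the scatter.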